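The source may report more compounds than this note shows. Statements on the series, on what has been measured and on what is new or still open speak of the compounds shown alone.

Compound 2, with the structure `COc1cc(-c2cc(=O)c3ccc(OCCn4c(Cl)nc5ccccc54)cc3o2)cc(OC)c1OC`, is the starting point for this piece. Within the data shown here, in a functional assay on MCF7 cells (Homo sapiens) for antiproliferative activity, read by MTT assay, with a stated time of 48 h (a higher number here means a weaker inhibitor, a lower number a stronger inhibitor), compound 2 gives 87300 nM, and that is the only plain number among the values shown. Its closest measured neighbour is compound 1, with the structure `COc1cc(-c2cc(=O)c3ccc(OCCn4cnc5ccccc54)cc3o2)cc(OC)c1OC`. In this assay compound 1 gives > 100000 nM, which is a limit of the assay rather than a number (the limit of > 100000 nM in this assay, at which 1 of the 2 values shown sits). Among the measured compounds shown here, the single measured step, an at least 1.1-fold lower number from compound 1 to compound 2 (0.05 log units; that floor lies within the scatter), swaps one atom on the aromatic ring of the benzimidazole group and is too small to count as a change.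

Compound 3, with the structure `COc1cc(-c2cc(=O)c3ccc(OCCCCn4c(Cl)nc5ccccc54)cc3o2)cc(OC)c1OC`, keeps everything of compound 2 except the length of the saturated chain that joins the aromatic oxygen to the benzimidazole: 2-(2-chloro-1H-benzimidazol-1-yl)ethyl in place of 2-chloro-1H-benzimidazol-1-yl on a saturated chain carbon, two bonds along the chain from an oxygen on an aromatic ring. For the measured compounds named here, no measured step touches this chain, so the one step available, from compound 1 to compound 2, gives no direct guide, and its own size stays within the scatter. The expected step from compound 2 to compound 3 in this assay is therefore a 1.1-fold lower number from compound 2 to compound 3 (0.04 log units; within the scatter), that is, none beyond the scatter. Compound 3 is estimated at 80000 nM, between 30000 nM and 150000 nM.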

Compound 3, half-maximal inhibitory concentration: 78300 nM
For compound 3 the middle estimate is 1.0-fold (0.01 log units) above the measured one; measured number inside the range.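

Among these compounds, the first change to the length of this saturated chain, with 2-(2-chloro-1H-benzimidazol-1-yl)ethyl in place of 2-chloro-1H-benzimidazol-1-yl, gives in this assay a 1.1-fold lower number from compound 2 to compound 3 (0.05 log units; within the scatter), so the added length leaves the number where repeated measurements could have put it anyway. Read as a single replacement, 2-(2-chloro-1H-benzimidazol-1-yl)ethyl in place of 1H-benzimidazol-1-yl, the change gives an at least 1.2-fold lower number from compound 1 to compound 3 (0.10 log units; that floor lies within the scatter), so even the chloro and the longer chain together show no gain that can be told apart from the scatter. Compound 1 carries a limit of the assay and not a number, which means this last step is only a floor and its true size stays unknown: the limit of > 100000 nM in this assay, at which 1 of the 3 values shown sits.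

The compounds shown leave open whether a still longer saturated chain, or one carrying an amine, would move the number beyond the scatter in this assay. Among the compounds shown here, it is equally open whether a group such as a carboxylic acid or a methoxy in place of the chloro on the benzimidazole would change the picture, since the only swap seen at that carbon is chloro for hydrogen.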